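Benzyloxy for methylsulfanyl at the assay limit

The compounds below may be only part of what the source reports. "The series", "measured", "known", "first", "only" and "open" are said of these compounds alone.

In an ADME assay on Huh-7 cells (Homo sapiens) for cytotoxicity, with a stated time of 72 h (a lower number here means that less compound is tolerated, a higher number that more compound is tolerated), compound 2 (`CSC(=O)CCCC(=O)n1c(=O)c(C)cn([C@@H]2O[C@H](CO[Si](C)(C)C(C)(C)C)[C@@]3(OS(=O)(=O)C=C3N)[C@H]2O[Si](C)(C)C(C)(C)C)c1=O`) gives > 100000 nM as a limit, not a number. Compound 1 (`Cc1cn([C@@H]2O[C@H](CO[Si](C)(C)C(C)(C)C)[C@@]3(OS(=O)(=O)C=C3N)[C@H]2O[Si](C)(C)C(C)(C)C)c(=O)n(C(=O)CCCC(=O)N(C)C)c1=O`) gives > 100000 nM as a limit too. For the measured compounds named here, that leaves the limit of > 100000 nM in this assay, at which 2 of the 2 values shown sit, as the only guide, and a step that the two limits leave unreadable from compound 1 to compound 2 offers no size to carry forward. Compound 3 (`Cc1cn([C@@H]2O[C@H](CO[Si](C)(C)C(C)(C)C)[C@@]3(OS(=O)(=O)C=C3N)[C@H]2O[Si](C)(C)C(C)(C)C)c(=O)n(C(=O)CCCC(=O)OCc2ccccc2)c1=O`) differs from compound 2 by benzyloxy in place of methylsulfanyl on a carbonyl carbon with benzyloxy in place of methylsulfanyl on a carbonyl carbon. No change beyond the scatter is expected, and no direction can be foreseen: the estimated step is a number no higher from compound 2 to compound 3 (the limit leaves the size open) and nothing larger. Compound 3 is estimated at 100000 nM with a range from 40000 nM to 200000 nM. A limit, not a number, is the expected outcome for compound 3 as well.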

Compound 3, half-maximal cytotoxic concentration: > 100000 nM
Compound 3 ended at the assay's limit; the forecaster's own chance of this, stated with the estimate: 85%; the middle value sits exactly at the limit.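

No new step can be read among compound 1, compound 2 and compound 3, since all three give a limit and not a number: the limit of > 100000 nM in this assay, at which 3 of the 3 values shown sit.

Going by these compounds, whether dimethylamino, methylsulfanyl and benzyloxy on the carbonyl carbon differ at all in this assay stays open.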